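Swapping the methoxyphenyl for a chlorophenyl on the hydrazone

A few compounds are considered here, and "the series" means these few. Any claim that something is new, unique, unknown or untested is made for them only; others in the source may bear on it.

Among the compounds with values here, compound 2 `COc1ccc(/C=N/NC(=S)NC(C)(C)[C@H]2CC=C(C)CC2)cc1` is the only member of this small set that returns a number in an ADME assay on Vero cells (Chlorocebus sabaeus) for inhibition, read by sulforhodamine B assay, with a stated time of 48 h; a lower number here means a stronger inhibitor of growth, a higher number a weaker inhibitor of growth: compound 2 gives 70100 nM. Compound 1 `CC1=CC[C@H](C(C)(C)N=C=S)CC1` gives only a limit, > 100000 nM. Compound 3 `CC1=CC[C@H](C(C)(C)NC(=S)N/N=C/c2ccc(N(C)C)cc2)CC1` likewise gives only a limit, > 100000 nM. Within the data shown here, the one step between measured compounds, an at least 1.4-fold higher number from compound 2 to compound 3 (0.15 log units; that floor lies within the scatter), is a floor rather than a full number because compound 3 sits at the limit of > 100000 nM in this assay, at which 2 of the 3 values shown sit. Compound 4 `CC1=CC[C@H](C(C)(C)NC(=S)N/N=C/c2cccc(Cl)c2)CC1` differs from compound 2 by 3-chlorophenyl in place of 4-methoxyphenyl on a carbon with a double bond to nitrogen. Among the measured compounds shown here, no measured step covers this change directly; the step from compound 2 to compound 3 is the only one on the same ring, and it did not move the read-out beyond the scatter in this assay. On that footing a small move toward a weaker inhibitor, or none beyond the scatter, is the reasonable expectation. Compound 4 is therefore expected to give about 90000 nM in this assay, within the range 35000 nM to 230000 nM, with a real chance that only a limit is reported. The expected step from compound 2 to compound 4 is a 1.3-fold higher number from compound 2 to compound 4 (0.11 log units; within the scatter).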

Compound 4, concentration for total growth inhibition: > 100000 nM
Compound 4: a limit, no number; the forecaster's own chance of this, stated with the estimate: 45%; middle value at least 1.1-fold (0.04 log units) from the limit.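

In this assay, 3-chlorophenyl in place of 4-methoxyphenyl on a carbon with a double bond to nitrogen gives an at least 1.4-fold higher number from compound 2 to compound 4 (0.15 log units; that floor lies within the scatter), and this is only a floor because compound 4 reports a limit, not a number: (the limit of > 100000 nM in this assay, at which 3 of the 4 values shown sit). Compound 3 and compound 4 now show that two different replacements for the 4-methoxyphenyl group, one changing the substituent and the other changing both substituent and its printed ring position, both end at a limit. Neither change gives any sign of a stronger inhibitor of growth, yet how far either compound lies past the floor cannot be read.

The compounds shown leave open whether any other group on this ring, such as a hydroxyl or a carboxylic acid, would return a number. They also leave open whether 4-chlorophenyl would behave as 3-chlorophenyl does.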